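Replacing methoxy with ethyl on the furan series

The source may hold more compounds than are shown below. What is called first, only, known or untested is meant among the compounds shown, and "the series" means these compounds.

Measured so far:
compound 1 `COc1cccc(Nc2nccc(-c3cc(C)oc3C)n2)c1`, 5800 nM
compound 2 `CCc1cccc(Nc2nccc(-c3ccsc3)n2)c1`, 1100 nM
compound 3 `COc1cccc(Nc2nccc(-c3ccco3)n2)c1`, 400 nM

In a functional assay for inhibition, with Homo sapiens as the target (a lower number here means a stronger inhibitor, a higher number a weaker inhibitor), compound 3 gives the lowest number of the three, compound 2 the next, compound 1 the highest; the single-place step a 15-fold lower number from compound 1 to compound 3 (1.16 log units; beyond the scatter) is large. Compound 4 `CCc1cccc(Nc2nccc(-c3ccco3)n2)c1` carries the change (ethyl in place of methoxy on an aromatic carbon). Among the compounds with values here, no measured pair isolates this change: compound 2 also bears ethyl, but differs from compound 3 in two places, so its value shows only that the ethyl-bearing compound 2 is not far from compound 3. The expected step of a 1.4-fold higher number from compound 3 to compound 4 (0.14 log units; within the scatter) is therefore small, perhaps within the scatter. The estimate for compound 4 is 550 nM, between 150 nM and 2000 nM.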

Compound 4, half-maximal inhibitory concentration: 9700 nM
Estimate against measurement, compound 4: 18-fold (1.25 log units) below; the measured number lies above the stated range.
By their numbers in this assay, from the lowest: compound 3; then compound 2; then compounds 1 and 4 (each within the scatter of the next).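

Read on its own for the first time, ethyl in place of methoxy on this aromatic carbon gives a 24-fold higher number from compound 3 to compound 4 (1.38 log units; beyond the scatter) in this assay, so this position does not tolerate the change. With ethyl held constant, furan-2-yl in place of thiophen-3-yl gives an 8.8-fold higher number from compound 2 to compound 4 (0.95 log units; beyond the scatter), so among these compounds furan-2-yl gives the lowest number only alongside methoxy. No measurement available here explains the loss. The compounds shown leave open how a hydroxyl, an amine or an ethoxy group would fare at this place, and how methoxy would read alongside thiophen-3-yl.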